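The compounds below may be only part of what the source reports. "The series", "measured", "known", "first", "only" and "open" are said of these compounds alone.

The measured compounds and their values in an ADME assay on NIH3T3 cells (Mus musculus) for antiproliferative activity, read by MTT assay, with a stated time of 72 h; a lower number here means a stronger inhibitor, a higher number a weaker inhibitor:
Compound 1, `O=C1NC(=O)/C(=C/C2=Cc3ccccc3OC2)S1`, gives > 200000 nM, which is a limit of the assay and not a number.
Compound 2, `O=C1NC(=S)S/C1=C\C1=Cc2ccccc2OC1`, gives 72400 nM.
Compound 3, `O=C1NC(=O)/C(=C/C2=Cc3cc(Br)ccc3OC2)S1`, gives 56500 nM.

Compound 1 and compound 3 share a core and differ by bromo in place of hydrogen on an aromatic carbon. That change gave an at least 3.5-fold lower number from compound 1 to compound 3 (0.54 log units; beyond the scatter), while the value of compound 1 sits at the limit of > 200000 nM in this assay, at which 1 of the 3 values shown sits. Compound 2 has a different core; the difference between the two cores is not broken down here. Compound 2 and compound 3 give numbers within the scatter of each other. Compound 4, `O=C1NC(=S)S/C1=C\C1=Cc2cc(Br)ccc2OC1`, has not been measured; it differs from compound 2 by bromo in place of hydrogen on an aromatic carbon, the same change, at the same place, that was made from compound 1 to compound 3. Compound 4 is expected to show a 3.3-fold lower number from compound 2 to compound 4 (0.52 log units; beyond the scatter) in this assay. This expectation rests on compound 2, at 72400 nM, and on the step of an at least 3.5-fold lower number from compound 1 to compound 3 (0.54 log units; beyond the scatter). Compound 4 is estimated at 22000 nM, between 7000 nM and 70000 nM.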

Compound 4, half-maximal inhibitory concentration: 27800 nM
For compound 4 the middle estimate is 1.3-fold (0.10 log units) below the measured one, within the range that was stated.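

In this assay, bromo in place of hydrogen on an aromatic carbon gave a 2.6-fold lower number from compound 2 to compound 4 (0.42 log units; beyond the scatter), so the number fell on both cores shown: the same change on two cores in this assay, an at least 3.5-fold lower number (0.54 log units; beyond the scatter) from compound 1 to compound 3 and a 2.6-fold lower number (0.42 log units; beyond the scatter) from compound 2 to compound 4; the limit leaves it open whether they differ. Compound 1 stands at a limit of the assay and not at a number, so the first step has no exact size and a match in size between the two cores is not shown: the limit of > 200000 nM in this assay, at which 1 of the 4 values shown sits. The result covers one change at one place on two cores, and it sets no rule for other cores.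

The compounds shown leave open what a chloro, a methoxy or an amine would do in place of the bromo on either core. They also leave open whether a carboxylic acid or a longer chain at that place would follow the same direction.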